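Swapping a hydroxyphenyl amide for a methylphenyl amide

The source may report more compounds than this note shows. Statements on the series, on what has been measured and on what is new or still open speak of the compounds shown alone.

Compound 1 `CN(C)C(=O)c1cc2cnc(Nc3ccc(NC(=O)C4(C(=O)Nc5cccc(O)c5)CC4)cc3)nc2n1C1CCCC1` is one of three related compounds tested in a functional assay on NCI-H1299 cells (Homo sapiens) for inhibition, read by CCK-8 assay, with a stated time of 72 h, tested at 10 uM (a higher number here means more inhibition of growth at the concentration tested, a lower number less inhibition of growth), where compound 1 gives 78.5%. Its number is the lowest of the three shown, yet neither companion is separated from it beyond the scatter: compound 2 `CN(C)C(=O)c1cc2cnc(Nc3ccc(NC(=O)C4(C(=O)Nc5ccc(F)cc5)CC4)cc3F)nc2n1C1CCCC1` gives 82.6%, and compound 3 `CN(C)C(=O)c1cc2cnc(Nc3ccc(NC(=O)C4(C(=O)Nc5cccc(Cl)c5)CC4)cc3)nc2n1C1CCCC1` gives 84.1%. The step from compound 1 to compound 3, which is chloro in place of hydroxy on an aromatic carbon, reads a number 5.6 percentage points higher from compound 1 to compound 3 (within the scatter).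

Compound 4 `Cc1ccc(NC(=O)C2(C(=O)Nc3ccc(Nc4ncc5cc(C(=O)N(C)C)n(C6CCCC6)c5n4)cc3)CC2)cc1` has not been measured. It differs from compound 1 by 4-methylphenyl in place of 3-hydroxyphenyl on an amide-type nitrogen. Among the measured compounds shown here, the only measured step touching this part of the molecule is the one to compound 3, which replaced the same hydroxy group and stayed within the scatter. On that basis no step beyond the scatter is expected in this assay for compound 4. The expected step is a number 2.5 percentage points higher from compound 1 to compound 4 (within the scatter). Compound 4 is estimated to give 81%, with a range from 70% to 90%.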

Compound 4, percent growth inhibition at one concentration: 84.5%
For compound 4 the middle estimate is 3.5 percentage points below the measured one; the measured number falls inside the stated range.
By their numbers in this assay, from the lowest: compounds 1, 2, 3 and 4 (each within the scatter of the next).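

In this assay, placing 4-methylphenyl on the amide-type nitrogen in place of 3-hydroxyphenyl gives a number 6 percentage points higher from compound 1 to compound 4 (within the scatter), so at this position the hydroxy group, with its hydrogen-bond donor and acceptor, can be lost without a step beyond the scatter. Set against the 3-chlorophenyl group, 4-methylphenyl reads a number 0.4 percentage points higher from compound 3 to compound 4 (within the scatter), which means that these two groups cannot be told apart in this read-out. Nothing available here explains why the three groups read alike.

Still open is whether a group of another kind on this aromatic ring, such as an amine or a carboxylic acid, would stay within the scatter of these compounds in this assay. Also open, on these data alone, is what a butyl chain in place of the whole ring would do, which would show whether this nitrogen needs an aromatic ring at all.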